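The source may report more compounds than this note shows. Statements on the series, on what has been measured and on what is new or still open speak of the compounds shown alone.

Measured so far:
Compound 1 `CCN(CC)C(=O)Cc1c(-c2ccc(OCC3CC3)cc2)nn2c(C)cc(C)nc12` gives 3 nM in an assay on isolated protein (kidney, strain Wistar) for displacement of a labelled ligand from Translocator protein (Rattus norvegicus), read by scintillation counting, with a stated time of 90 min; on this read-out lower numbers stand for stronger inhibition and higher numbers for weaker inhibition.
Compound 2 `CCN(CC)C(=O)Cc1c(-c2ccc(OCc3ccccc3)cc2)nn2c(C)cc(C)nc12` gives 0.99 nM in this assay.

Compound 1 has the highest of the two numbers on hand, so it is the weaker of the two measured compounds; its nearest neighbour is compound 2, reached by a 3.0-fold lower number from compound 1 to compound 2 (0.48 log units; beyond the scatter). The unmeasured compound 3 `CCN(CC)C(=O)Cc1c(-c2ccc(OCc3ccc(F)cc3)cc2)nn2c(C)cc(C)nc12` differs from compound 1 by 4-fluorophenyl in place of cyclopropyl on a saturated chain carbon bound to an oxygen on an aromatic ring. Going by the values given here, the only measured step that bears on this is the one from compound 1 to compound 2, where a phenyl in place of the cyclopropyl on the same saturated chain carbon gave a modest gain beyond the scatter. Compound 3 carries a 4-fluorophenyl at that place, which shares the six-membered aromatic ring with compound 2 and adds one fluorine. Among the compounds with values here, no measured step shows the effect of that fluorine alone, so the expectation rests on the phenyl step. Compound 3 is therefore expected to land close to compound 2, at 1.1 nM with a range of 0.4 nM to 3 nM. This estimate means a step of a 2.7-fold lower number from compound 1 to compound 3 (0.44 log units; beyond the scatter).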

Compound 3, inhibition constant: 0.77 nM
For compound 3 the middle estimate is 1.4-fold (0.15 log units) above the measured one; the measured number falls inside the stated range.
By their numbers in this assay, from the lowest: compounds 3 and 2 (each within the scatter of the next); then compound 1.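

In this assay, the change from cyclopropyl to 4-fluorophenyl gives a 3.9-fold lower number from compound 1 to compound 3 (0.59 log units; beyond the scatter), so a second group with a six-membered aromatic ring, on the saturated chain carbon bound to an oxygen on an aromatic ring, also stands clear of the cyclopropyl compound. The new information is the fluorine: fluoro in place of hydrogen on an aromatic carbon gives a 1.3-fold lower number from compound 2 to compound 3 (0.11 log units; within the scatter), which means that this one added atom makes no readable difference here and that the compounds with phenyl and 4-fluorophenyl at this place cannot be told apart. Nothing on hand explains why either ring goes with a lower number than cyclopropyl does.

The compounds shown leave open what a methoxy, a trifluoromethyl or an amine would do in place of that fluoro, as a single fluorine says little about other groups on the ring. They also leave open whether an aromatic ring is needed at all, a question that a cyclohexyl in place of the cyclopropyl could answer by keeping a six-membered ring without the aromatic character.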